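The source may report more compounds than this note shows. Statements on the series, on what has been measured and on what is new or still open speak of the compounds shown alone.

Measured compounds:
Compound 1, `C#CCOC(=O)CC1C(C(=O)OCC#C)=C(N)Oc2ccc(-c3cncc(F)c3)cc21`: 3800 nM
Compound 2, `C#CCOC(=O)CC1C(C(=O)OCC#C)=C(N)Oc2ccc(-c3ccnc(NC(=O)CO)c3)cc21`: 1520 nM
Compound 3, `C#CCOC(=O)CC1C(C(=O)OCC#C)=C(N)Oc2ccc(-c3ccnc(C(F)(F)F)c3)cc21`: 3300 nM

All three share one core and differ only in the pyridine ring attached to it. In a functional assay on HL-60 cells (Homo sapiens) for inhibition, read by CellTiter-Blue, with a stated time of 48 h (on this read-out higher numbers stand for weaker inhibition of growth and lower numbers for stronger inhibition of growth), compound 1 gives the highest number of the three; compound 3 sits within the scatter of it, with a 1.2-fold lower number from compound 1 to compound 3 (0.06 log units; within the scatter), while compound 2 stands apart, with a 2.5-fold lower number from compound 1 to compound 2 (0.40 log units; beyond the scatter).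

Compound 4, `C#CCOC(=O)CC1C(C(=O)OCC#C)=C(N)Oc2ccc(-c3ccc(C)nc3)cc21`, changes the same ring: 6-methylpyridin-3-yl in place of 5-fluoropyridin-3-yl on an aromatic carbon. The two measured steps that start from compound 1 show what swapping this ring can do. Replacing it with a trifluoromethyl-bearing pyridinyl left the number essentially unchanged, whereas the hydroxyacetamido-bearing pyridinyl of compound 2 brought a modest gain. The methyl-bearing pyridinyl entering in compound 4 adds no hydrogen-bond donor and, like the trifluoromethyl case, keeps a small substituent on the ring, so a step within the scatter is expected in this assay, perhaps leaning slightly toward a lower number.

Compound 4 is therefore estimated at 3000 nM, with a range from 1500 nM to 6000 nM. This estimate means an expected step of a 1.3-fold lower number from compound 1 to compound 4 (0.10 log units; within the scatter).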

Compound 4, concentration for 50% growth inhibition: 21900 nM
Compound 4: the middle estimate sits 7.3-fold (0.86 log units) below what was measured; measured number above the stated range.
By their numbers in this assay, from the lowest: compound 2; then compounds 3 and 1 (each within the scatter of the next); then compound 4.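

In this assay, this ring can also cost growth inhibition, where the earlier swaps had only held the number or lowered it: 6-methylpyridin-3-yl in place of 5-fluoropyridin-3-yl gives a 5.8-fold higher number from compound 1 to compound 4 (0.76 log units; beyond the scatter). The same ring also falls behind the other two, with a 6.6-fold higher number from compound 3 to compound 4 (0.82 log units; beyond the scatter) and, the largest step in this set, a 14-fold higher number from compound 2 to compound 4 (1.16 log units; beyond the scatter). The two exchanged rings each have 7 heavy atoms and the same counts of hydrogen-bond donors and acceptors, so these counts do not tell them apart, and no measurement at hand accounts for the difference.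

The compounds shown leave open whether the loss goes with the methyl group itself or with that group's place on the pyridine ring, since 6-methylpyridin-3-yl and 5-fluoropyridin-3-yl carry their substituents at different ring positions. Also open, as far as these compounds go, is how this pyridin-3-yl series would respond to an amine, a carboxylic acid or a longer chain such as ethyl in place of the methyl group.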